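A few compounds are considered here, and "the series" means these few. Any claim that something is new, unique, unknown or untested is made for them only; others in the source may bear on it.

Notes on the series. Compound 1 `CC[C@H](C)C(=O)O[C@H]1CCC=C2C=C[C@H](C)[C@H](CCC(=O)C[C@@H](O)CC(=O)O)[C@H]21` gives 32 nM in an assay on microsomes from liver for inhibition of 3-hydroxy-3-methylglutaryl-coenzyme A reductase (Rattus norvegicus); a higher number here means a weaker inhibitor, a lower number a stronger inhibitor. Compound 2 `CC[C@H](C)C(=O)O[C@@H]1CCC=C2C=C[C@@H](C)[C@@H](COC(=O)CCCC(=O)O)[C@@H]21` gives 110000 nM in this assay, and compound 3 `CC[C@H](C)C(=O)O[C@H]1CCC=C2C=C[C@H](C)[C@H](COC(=O)C[C@H](O)CC(=O)O)[C@H]21` gives 5000 nM in this assay. Compound 3 thus holds the second highest of the three numbers, beyond the scatter from both neighbours, nearer to compound 2 and far from compound 1. Compound 4 `CC[C@H](C)C(=O)O[C@@H]1CCC=C2C=C[C@@H](C)[C@@H](COC(=O)C[C@H](O)CC(=O)O)[C@@H]21` is not yet measured in this assay. It differs from compound 3 as follows: the two compounds have the same atoms and bonds and differ only in configuration as drawn: 4 of 6 stereo elements differ; a stereocentre at a saturated ring carbon is drawn S in compound 3 and R in compound 4; a stereocentre at a saturated ring carbon is drawn S in compound 3 and R in compound 4; a stereocentre at a saturated ring carbon is drawn S in compound 3 and R in compound 4; a stereocentre at a saturated ring carbon is drawn R in compound 3 and S in compound 4. Compound 4 shares its ring configuration with compound 2, which gives 110000 nM in this assay, while compound 3 shares its ring configuration with compound 1. For compound 4 a weakening beyond the scatter is expected in this assay, a step of a 12-fold higher number from compound 3 to compound 4 (1.08 log units; beyond the scatter). Compound 4 is estimated at 60000 nM, within 10000 nM to 400000 nM.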

Compound 4, half-maximal inhibitory concentration: 25000 nM
Beside the measured number, compound 4's estimate is 2.4-fold (0.38 log units) above it; measured number inside the range.
By their numbers in this assay, from the lowest: compound 1; then compound 3; then compound 4; then compound 2.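

In this assay, configuration alone moves the number, a 5.0-fold higher number from compound 3 to compound 4 (0.70 log units; beyond the scatter), so the ring configuration of compound 3 is favoured over that of compound 4, and the structures offer no other source for this step: the fact that compounds 3 and 4 differ only in the configuration as drawn. Within the ring configuration of compound 2, hydroxy in place of hydrogen on a saturated chain carbon bound to two saturated chain carbons also counts, a 4.4-fold lower number from compound 2 to compound 4 (0.64 log units; beyond the scatter). Both steps are modest, yet beyond the scatter.

On these data alone, what this hydroxy contributes on the ring configuration of compound 3 remains open, as does the effect of an amine in its place.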